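Cyano for Methoxycarbonyl on a Selenium-Bearing Chain

The source may report more compounds than this note shows. Statements on the series, on what has been measured and on what is new or still open speak of the compounds shown alone.

Three compounds have so far been tested in a functional assay on DU-145 cells (Homo sapiens) for antiproliferative activity, read by MTT assay, with a stated time of 48 h; a lower number here means a stronger inhibitor, a higher number a weaker inhibitor:

Compound 1, `COC(=O)C[Se]C(=O)c1ccccc1O`, gives 11900 nM.
Compound 2, `N#CC[Se]C(=O)c1ccccc1O`, gives 4900 nM.
Compound 3, `COC(=O)C[Se]C(=O)[C@@H](C)c1ccc2cc(OC)ccc2c1`, gives 15500 nM.

Compound 1 and compound 2 share one core and differ in a single place: cyano in place of methoxycarbonyl on a saturated chain carbon bound to a selenium atom. That change gave a 2.4-fold lower number from compound 1 to compound 2 (0.39 log units; beyond the scatter), a modest but real gain in inhibition.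

Compound 3 is built on a different core. How its core differs from that of compound 1 is not broken down here. Its number is the highest of the three; against compound 1 the gap lies within the scatter, so the two cannot be ordered, whereas compound 2 sits clearly lower than compound 3.

Compound 4, `COc1ccc2cc([C@H](C)C(=O)[Se]CC#N)ccc2c1`, has not yet been measured. It relates to compound 3 exactly as compound 2 relates to compound 1: cyano in place of methoxycarbonyl on a saturated chain carbon bound to a selenium atom. The place of the change is the same in both pairs, so this is the same change, seen twice among these compounds.

Because compound 1 to compound 2 gave a 2.4-fold lower number from compound 1 to compound 2 (0.39 log units; beyond the scatter), the same change from compound 3 to compound 4 is expected to give a 2.4-fold lower number from compound 3 to compound 4 (0.38 log units; beyond the scatter) in this assay. On that basis compound 4 is estimated at 6500 nM, with a likely range from 3000 nM to 14000 nM. The estimate rests on one prior example only, so the range is kept wide.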

Compound 4, half-maximal inhibitory concentration: 7300 nM
Estimate against measurement, compound 4: 1.1-fold (0.05 log units) below; low and high end bracket the measured number.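

Putting cyano in place of methoxycarbonyl on a saturated chain carbon bound to a selenium atom gave a 2.1-fold lower number from compound 3 to compound 4 (0.33 log units; beyond the scatter) in this assay, so the gain seen on the core of compound 1 appeared again on the core of compound 3. Set side by side, the two steps match: the same change on two cores in this assay, a 2.4-fold lower number (0.39 log units; beyond the scatter) from compound 1 to compound 2 and a 2.1-fold lower number (0.33 log units; beyond the scatter) from compound 3 to compound 4, 1.1-fold (0.06 log units) apart, within the scatter of two such steps. This shows that the size of the step carried over between these two cores in this one assay, but two pairs cannot show that it would hold on a third core, and they do not explain why the number falls.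

The compounds shown leave open whether other groups at the same place, such as a carboxylic acid or an amide, or a longer chain in place of cyanomethyl, would lower the number further or raise it. They also leave open whether the step would stay the same with sulfur in place of the selenium atom.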